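The source may hold more compounds than are shown below. What is called first, only, known or untested is meant among the compounds shown, and "the series" means these compounds.

Compound 1, with the structure `COc1cccc(-c2c(S(=O)(=O)c3ccc(OC)c(Cl)c3)cnc3cc(F)ccc23)c1`, was tested in an ADME assay on microsomes from liver (Homo sapiens) for metabolic stability, tested at 2.5 uM (a higher number here means faster removal of the compound, a lower number slower removal), and gave 1.71 mL/min. Compound 2, `O=S(=O)(c1ccc(F)c(Cl)c1)c1cnc2cc(F)ccc2c1-c1cccc(Cl)c1`, gave 0.66 mL/min in this assay. Of these two numbers, compound 1 gives the higher one, and its gap to compound 2 lies beyond the usual scatter of repeated measurements, so compound 1 is removed faster than compound 2. Within the data shown here, no pair of measured compounds differs in only one place, so there is no calibrated single step to lean on.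

Compound 3, `COc1cccc(-c2c(S(=O)(=O)c3cc(F)cc(F)c3)cnc3cc(F)ccc23)c1`, has not yet been measured in this assay. It differs from compound 1 in one place: 3,5-difluorophenyl in place of 3-chloro-4-methoxyphenyl on a sulfonyl sulfur. Compound 2 also carries a different ring on the sulfonyl sulfur and gave the lower number 0.66 mL/min, which gives some precedent for a lower result when that ring is changed. On that basis the step of a 1.7-fold lower number from compound 1 to compound 3 (0.23 log units; within the scatter) is expected to be a moderate decrease, close to the edge of the usual scatter. The value for compound 3 is estimated at 1 mL/min, within a range from 0.5 mL/min to 2 mL/min.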

Compound 3, intrinsic clearance in a liver preparation (reported as CLH), per the amount of preparation that the assay uses: 1.81 mL/min
Compound 3: middle estimate off by 1.8-fold (0.26 log units), on the low side; the measured number falls inside the stated range.
By their numbers in this assay, from the lowest: compound 2; then compounds 1 and 3 (each within the scatter of the next).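

In this assay, among these compounds, putting 3,5-difluorophenyl in place of 3-chloro-4-methoxyphenyl on a sulfonyl sulfur gives a 1.1-fold higher number from compound 1 to compound 3 (0.02 log units; within the scatter), the first step in this set that isolates a single place in the molecule. The exchange is far from trivial on paper: the group that leaves carries chlorine, oxygen and 1 hydrogen-bond acceptor, while the group that enters carries two fluorine atoms and 0 hydrogen-bond acceptors, and still the numbers of the two compounds lie within the usual scatter of each other, so for this pair the assay cannot tell the two rings apart. No measurement here speaks to the reason for this.

From the compounds shown here alone, what remains open is whether a ring on the sulfonyl sulfur that carries an amine or a carboxylic acid, or a longer chain in place of the ring, would give a step beyond the scatter. Also open, going by these compounds, is whether the same exchange of rings would read the same way on a core other than that of compound 1, since this single step comes from one pair of compounds only.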